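A few compounds are considered here, and "the series" means these few. Any claim that something is new, unique, unknown or untested is made for them only; others in the source may bear on it.

Values in an ADME assay on S9 fraction from liver (Rattus norvegicus) for metabolic stability, read by LC-MS, using NADPH, with a stated time of 30 min; a lower number here means that less of the compound is left, a higher number that more of the compound is left:

- Compound 1 `CCCCCCCCc1ccc(OCC(=O)Cn2nnc(SC)n2)cc1`: < 5% (a limit)
- Compound 2 `CCCCCCCCc1ccc(OCC(=O)Cn2nnc(-c3cccc(Cl)c3)n2)cc1`: 69%
- Compound 3 `CCCCCCCCc1ccc(OCC(=O)Cn2nnc(-c3ccc(C(=O)O)cc3)n2)cc1`: < 5% (a limit)

Compound 3 gives < 5% in this assay, and this is a limit of the assay, not a number. Compound 3 thus stands with compound 1 at the limit of < 5% in this assay, at which 2 of the 3 values shown sit. Compound 4 `CCCCCCCCc1ccc(OCC(=O)Cn2nnc(-c3cccc(C(=O)O)c3)n2)cc1` has the same atoms joined differently, with 3-carboxyphenyl in place of 4-carboxyphenyl on an aromatic carbon of a five-membered aromatic ring with 4 nitrogen (3-carboxyphenyl in place of 4-carboxyphenyl on an aromatic carbon).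

Going by the values given here, no measured step makes this exact exchange, so the evidence is indirect. The large step of a number at least 64 percentage points higher from compound 1 to compound 2 (beyond the scatter) and the equally large step a number at least 64 percentage points lower from compound 2 to compound 3 (beyond the scatter) both involve compound 2, which carries 3-chlorophenyl and no carboxyphenyl group. The step that the two limits leave unreadable from compound 1 to compound 3 cannot be sized. Compound 4 remains a carboxyphenyl compound like compound 3, so it is expected to stay close to it, though compound 2 at 69% leaves some room for a rise. The expected step is a number at least 3 percentage points higher from compound 3 to compound 4 (that floor lies within the scatter), which would be small and not beyond the scatter. For compound 4 the estimated value is 8%, with an expected range from 3% to 30%.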

Compound 4, percent of the compound remaining: < 5%
Compound 4: no number, only a limit; the forecaster's own chance of this, stated with the estimate: 55%; at least 3 percentage points between middle value and limit.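

Moving the carboxy group, with 3-carboxyphenyl in place of 4-carboxyphenyl, left the compound at the bottom of the range of this assay: compound 4 gives < 5%, which is a limit of the assay and not a number. Carboxy in place of chloro, an exchange that leaves the rest of the 3-substituted phenyl group unchanged, gives a number at least 64 percentage points lower from compound 2 to compound 4 (beyond the scatter). The steps from compound 1 and from compound 3 to compound 4 cannot be read, and the values now gather at one end: the limit of < 5% in this assay, at which 3 of the 4 values shown sit.

Going by these compounds, whether compound 3 and compound 4 differ beneath that limit stays open. Also open, on these data alone, is how a methyl ester or an amide in place of carboxy on this phenyl group would read in this assay, and whether a 4-chlorophenyl group would behave like 3-chlorophenyl.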